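A few compounds are considered here, and "the series" means these few. Any claim that something is new, unique, unknown or untested is made for them only; others in the source may bear on it.

Results in a functional assay on HT-29 cells (Homo sapiens) for inhibition, read by MTT assay, with a stated time of 2 days; a higher number here means a weaker inhibitor, a lower number a stronger inhibitor:
- compound 1 `COc1ccccc1/C=C/c1ccccc1O` gives 23 ug/mL
- compound 2 `Nc1cccc(/C=C/c2ccccc2O)c1` gives 30.4 ug/mL
- compound 3 `Nc1ccc(/C=C/c2cccc(O)c2)cc1` gives 42 ug/mL

Compound 3 lies within the usual scatter of both other compounds, so the three cannot be ranked. Compound 4 `COc1ccc(/C=C/c2cccc(O)c2)cc1` has methoxy in place of amino on an aromatic carbon, para to a group of 9 heavy atoms (methoxy in place of amino on an aromatic carbon). Among the measured compounds shown here, no measured pair shows this change directly. Still, compound 1, which carries methoxy, gives 23 ug/mL, and compound 2, which carries amino, gives 30.4 ug/mL, values within the scatter of each other. No step beyond the scatter is therefore expected. The expected change is a 1.3-fold lower number from compound 3 to compound 4 (0.10 log units; within the scatter). For compound 4 the estimated value is 33 ug/mL, with an expected range of 14 ug/mL to 75 ug/mL.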

Compound 4, half-maximal inhibitory concentration: 22 ug/mL
Compound 4: the middle estimate sits 1.5-fold (0.18 log units) above what was measured; measured number inside the range.
By their numbers in this assay, from the lowest: compounds 4, 1, 2 and 3 (each within the scatter of the next).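

Among the compounds shown here, this is the first direct comparison of methoxy and amino on an aromatic carbon para to a group of 9 heavy atoms: in this assay, the change gives a 1.9-fold lower number from compound 3 to compound 4 (0.28 log units; within the scatter). That step lies within the scatter, so the two groups cannot be told apart at this position, even though amino's hydrogen-bond donor is lost. No supporting measurement is available to explain this result. Still open, from the compounds shown here alone, is whether a different group here, such as a carboxylic acid, a chlorine or a longer alkoxy chain, would move the number beyond the scatter.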